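Aryl variation on the pyrrolidine carbon of the piperazine amide series

This account rests on a few compounds, and the source may have more. Where it says the series, first, only, none or still open, it means among the compounds named here.

Measured so far in an assay on HEK293 cells for displacement of a labelled ligand from Melanocortin receptor 4 (Homo sapiens); a higher number here means a weaker inhibitor, a lower number a stronger inhibitor:
- compound 1, `CC(C)[C@H](NC(=O)CCN(C)C)c1cccc(F)c1N1CCN(C(=O)[C@@H]2CN(C(C)C)C[C@H]2c2cc(F)c(F)c(F)c2)CC1`, gives 250 nM
- compound 2, `Cc1cccc([C@@H]2CN(C(C)C)C[C@H]2C(=O)N2CCN(c3c(F)cccc3[C@@H](NC(=O)CCN(C)C)C(C)C)CC2)c1`, gives 470 nM

Among the measured compounds shown here, only one step between measured compounds is available: replacing 3,4,5-trifluorophenyl with 3-methylphenyl on the saturated ring carbon gave a 1.9-fold higher number from compound 1 to compound 2 (0.27 log units; within the scatter). Compound 2 and compound 1 therefore sit within the scatter of one another in this assay, and nothing further can be said about their order.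

Compound 3, `CC(C)[C@H](NC(=O)CCN(C)C)c1cccc(F)c1N1CCN(C(=O)[C@@H]2CN(C(C)C)C[C@H]2c2cc(F)ccc2F)CC1`, has not yet been measured in this assay. It differs from compound 2 as follows: 2,5-difluorophenyl in place of 3-methylphenyl on a saturated ring carbon. For the measured compounds named here, the only step that bears on this change is the one from compound 1 to compound 2, and that step stayed within the scatter. A difluorophenyl group lies between the two aryl groups already seen in the number of fluorine atoms, so no step beyond the scatter is expected in this assay; the expected step from compound 2 is a 1.5-fold lower number from compound 2 to compound 3 (0.17 log units; within the scatter). Compound 3 is estimated at 320 nM, with a range from 120 nM to 850 nM.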

Compound 3, inhibition constant: 2050 nM
Compound 3: the middle estimate sits 6.4-fold (0.81 log units) below what was measured; the measured number lies above the stated range.
By their numbers in this assay, from the lowest: compounds 1 and 2 (each within the scatter of the next); then compound 3.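

In this assay, the aryl group on this saturated ring carbon, next to the ring atom that bears a large group, now clearly matters: 2,5-difluorophenyl gives a 4.4-fold higher number from compound 2 to compound 3 (0.64 log units; beyond the scatter) and an 8.2-fold higher number from compound 1 to compound 3 (0.91 log units; beyond the scatter), making compound 3 the weakest inhibitor of the three, whereas the earlier aryl change stayed within the scatter. The fluorine count of the aryl group does not order the three numbers, since 3-methylphenyl and 3,4,5-trifluorophenyl remain within the scatter of each other while 2,5-difluorophenyl, with a fluorine count that falls between theirs, stands apart from both. No measurement shown here accounts for this loss of binding strength.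

The three compounds cannot separate the contributions of the two fluorine atoms in 2,5-difluorophenyl, and they do not show how an unsubstituted phenyl, a monofluorophenyl or a pyridine ring would read in this assay. As far as these compounds go, it also remains open whether the same aryl dependence would hold with a cyclopropyl group in place of the isopropyl group on the ring nitrogen.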